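Series notes: oxazolidinedione chain length on the shared core

The compounds below may be only part of what the source reports. "The series", "measured", "known", "first", "only" and "open" are said of these compounds alone.

Measured so far:
compound 1 `CC(C)[C@@H](c1ccc(-c2ccc3cccc(F)c3c2)[nH]c1=O)[C@@H]1OC(=O)NC1=O` — 610 nM
compound 2 `CC(C)[C@H](C[C@H]1OC(=O)NC1=O)c1ccc(-c2ccc3cccc(F)c3c2)[nH]c1=O` — 15 nM
compound 3 `CC(C)C(/C=C1\OC(=O)NC1=O)c1cc(Cl)c(-c2ccc3cccc(F)c3c2)[nH]c1=O` — 360 nM

In a functional assay on CHO cells for antagonist activity at prostaglandin E2 receptor EP3 subtype (Homo sapiens), read by cAMP accumulation, with a stated time of 30 min (a higher number here means a weaker inhibitor, a lower number a stronger inhibitor), compound 2 gives the lowest number of the three. Compound 1, which carries the shorter link, gives 610 nM in this assay, and compound 3, with its own core, gives 360 nM; against these, compound 2 sits well apart.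

Compound 4 `CC(C)[C@@H](c1ccc(-c2ccc3cccc(F)c3c2)[nH]c1=O)[C@H]1OC(=O)NC1=O` is unmeasured. Relative to compound 2 the change is 2,4-dioxo-1,3-oxazolidin-5-yl in place of (2,4-dioxo-1,3-oxazolidin-5-yl)methyl on a saturated chain carbon bound to an aromatic carbon and a saturated chain carbon. Among the measured compounds shown here, this is the reverse of the one measured step that bears on it: a 41-fold lower number from compound 1 to compound 2 (1.61 log units; beyond the scatter). Undoing that change should therefore give a large rise in this assay, back toward the region of compound 1. The entering group carries its own defined stereocentre, so compound 4 need not repeat compound 1 exactly, and the range is kept wide.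

Compound 4 is therefore expected at 500 nM, with a range of 100 nM to 3000 nM, meaning an expected step of a 33-fold higher number from compound 2 to compound 4 (1.52 log units; beyond the scatter).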

Compound 4, half-maximal inhibitory concentration: 92 nM
For compound 4 the middle estimate is 5.4-fold (0.74 log units) above the measured one, outside the stated range (below it).
By their numbers in this assay, from the lowest: compound 2; then compound 4; then compounds 3 and 1 (each within the scatter of the next).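

In this assay, the configuration at the saturated ring carbon moves the number by itself, giving a 6.6-fold lower number from compound 1 to compound 4 (0.82 log units; beyond the scatter). This shift is assigned to that stereocentre alone, on this ground: the fact that compounds 1 and 4 differ only in the configuration as drawn. The link therefore cannot be judged from a 41-fold lower number from compound 1 to compound 2 (1.61 log units; beyond the scatter) alone: with the ring carbon drawn R, 2,4-dioxo-1,3-oxazolidin-5-yl in place of (2,4-dioxo-1,3-oxazolidin-5-yl)methyl gives the smaller 6.1-fold higher number from compound 2 to compound 4 (0.79 log units; beyond the scatter), so chain length and configuration both bear on the number.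

The compounds shown do not tell how the opposite ring-carbon configuration behaves on the (2,4-dioxo-1,3-oxazolidin-5-yl)methyl chain of compound 2. They also leave open whether a longer chain, or a carboxylic acid in place of the 2,4-dioxo-1,3-oxazolidin-5-yl ring, would hold the number of compound 2 on the shared core.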